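The source may report more compounds than this note shows. Statements on the series, on what has been measured and on what is new or still open speak of the compounds shown alone.

Compound 1 `N#CC1=C(N)Oc2c(c3nc4ccccc4nc3c3ccccc23)C12C(=O)N(Cc1cnnn1-c1ccc(F)c(Cl)c1)c1ccccc12` reaches only the limit of a functional assay on A549 cells (Homo sapiens) for antiproliferative activity, read by MTT assay, with a stated time of 48 h (a higher number here means a weaker inhibitor, a lower number a stronger inhibitor), recorded as > 50000 nM. Compound 2 `Cc1cccc(-n2nncc2CN2C(=O)C3(C(C#N)=C(N)Oc4c(N)cc5nc6ccccc6nc5c43)c3ccccc32)c1` holds the only number shown: in this assay compound 2 gives 12300 nM. The one other result, that of compound 1, is a limit rather than a number. Compound 3 `Cc1cc(C)cc(-n2nncc2CN2C(=O)C3(C(C#N)=C(N)Oc4c(N)cc5nc6ccccc6nc5c43)c3ccccc32)c1` has not yet been measured; it differs from compound 2 by methyl in place of hydrogen on an aromatic carbon. Among the measured compounds shown here, no measured pair shows what such a change does here. The step is expected to be small, a 1.2-fold lower number from compound 2 to compound 3 (0.09 log units; within the scatter), no larger than the usual scatter of this assay. Compound 3 is therefore estimated at 10000 nM, with a likely range from 4000 nM to 30000 nM.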

Compound 3, half-maximal inhibitory concentration: 31200 nM
Beside the measured number, compound 3's estimate is 3.1-fold (0.49 log units) below it, and the stated range ends below it.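

Going from 3-methylphenyl to 3,5-dimethylphenyl gives a 2.5-fold higher number from compound 2 to compound 3 (0.40 log units; beyond the scatter). The step is modest, but it shows that this ring position is not indifferent: one added methyl here weakens the antiproliferative effect. Both compounds lie toward the weak end of the scale, where readings give way to a limit: the limit of > 50000 nM in this assay, at which 1 of the 3 values shown sits.

Whether any group on this carbon would weaken the effect, or only methyl, stays open: a methoxy group, an amine or a fluorine here is not among the compounds shown. A single step also cannot show whether a stronger compound can be reached from this position.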